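This account rests on a few compounds, and the source may have more. Where it says the series, first, only, none or still open, it means among the compounds named here.

Compound 1 `COc1ccc(C2CC3(N(C)C)CC(O)C2C(c2ccc(OC)cc2)C3)cc1` gives 63400 nM
Compound 2 `COc1ccc(C2CC3(N4CCCC4)CC(O)C2C(c2ccc(OC)cc2)C3)cc1` gives 17900 nM
Compound 3 `CN(C)C12CC(O)C(C(c3ccc(Cl)cc3)C1)C(c1ccc(Cl)cc1)C2` gives 8770 nM

In an ADME assay on L6 cells (Rattus norvegicus) for cytotoxicity (a higher number here means a weaker inhibitor, a lower number a stronger inhibitor), compound 3 has the lowest number of the three, with compound 2 nearest and compound 1 furthest. Compound 4 `OC1CC2(N3CCCC3)CC(c3ccc(Cl)cc3)C1C(c1ccc(Cl)cc1)C2` is not yet measured. It carries pyrrolidin-1-yl in place of dimethylamino on a saturated ring carbon. The same replacement has been measured only once, on the core of compound 1, and it gave a 3.5-fold lower number from compound 1 to compound 2 (0.55 log units; beyond the scatter), a modest step beyond the scatter. Taking that single pair as a loose guide, a step of similar size towards a lower number is expected in this assay. The expected change is a 3.2-fold lower number from compound 3 to compound 4 (0.51 log units; beyond the scatter). For compound 4 the estimated value is 2700 nM (expected range 1100 nM to 6500 nM).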

Compound 4, half-maximal inhibitory concentration: 3590 nM
Compound 4: middle estimate off by 1.3-fold (0.12 log units), on the low side, within the range that was stated.
By their numbers in this assay, from the lowest: compound 4; then compound 3; then compound 2; then compound 1.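

In this assay, pyrrolidin-1-yl in place of dimethylamino on the saturated ring carbon gives a 2.4-fold lower number from compound 3 to compound 4 (0.39 log units; beyond the scatter) on the core bearing 4-chlorophenyl groups. The drop seen on the core of compound 1 is therefore not confined to that core. The two steps agree in direction and, within the scatter, in size: the same change on two cores in this assay, a 3.5-fold lower number (0.55 log units; beyond the scatter) from compound 1 to compound 2 and a 2.4-fold lower number (0.39 log units; beyond the scatter) from compound 3 to compound 4, 1.4-fold (0.16 log units) apart, within the scatter of two such steps.

From the compounds shown here alone, whether a piperidin-1-yl ring or a primary amine on this carbon would lower the number further remains open. The compounds shown also cannot explain why this change lowers it.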